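Swapping a furanylmethyl amine for a hydroxymethoxybenzyl amine

The compounds below may be only part of what the source reports. "The series", "measured", "known", "first", "only" and "open" are said of these compounds alone.

Compound 3 `Fc1ccc(-c2ccc3c(NCCCNCc4ccco4)ccnc3c2)cc1` gives 32000 nM in a physicochemical assay for solubility, with a stated time of 18 h, at pH 7.4; a lower number here means a less soluble compound, a higher number a more soluble compound. That number is level with compound 1 `COc1ccc(-c2ccc3c(NCCCNCc4cccc(OC)c4O)ccnc3c2)cc1`, which gives 32000 nM in this assay, and together they are the highest of the three; compound 2 `COc1cccc(CNCCCNc2ccnc3cc(C4CCCCC4)ccc23)c1O` gives 4200 nM. Going by the values given here, the only single-place step measured, a 7.6-fold lower number from compound 1 to compound 2 (0.88 log units; beyond the scatter), concerns the group on the aromatic carbon, not the chain end. Compound 4 `COc1cccc(CNCCCNc2ccnc3cc(-c4ccc(F)cc4)ccc23)c1O` differs from compound 3 by 2-hydroxy-3-methoxyphenyl in place of furan-2-yl on a saturated chain carbon bound to an amine nitrogen. Among the compounds with values here, no measured step covers this change directly, but compounds 1 and 3 show the same reading while differing at both positions. A step of no more than the scatter is therefore expected, no change at the digits printed from compound 3 to compound 4 (within the scatter), so compound 4 is estimated at 32000 nM with a range from 12000 nM to 80000 nM.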

Compound 4, solubility: 32000 nM
For compound 4 middle estimate and measured number coincide at the digits printed; measured number inside the range.
By their numbers in this assay, from the lowest: compound 2; then compounds 1, 3 and 4 (each within the scatter of the next).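

In this assay, the swap at the saturated chain carbon bound to an amine nitrogen, now read on its own, gives no change at the digits printed from compound 3 to compound 4 (within the scatter), so furan-2-yl and 2-hydroxy-3-methoxyphenyl read alike there with 4-fluorophenyl on the core. With 2-hydroxy-3-methoxybenzyl held fixed, fluoro in place of methoxy gives no change at the digits printed from compound 1 to compound 4 (within the scatter), while 4-fluorophenyl in place of cyclohexyl gives a 7.6-fold higher number from compound 2 to compound 4 (0.88 log units; beyond the scatter), so the aromatic-carbon group still separates these compounds. No supporting measurement explains either result. As far as these compounds go, whether a pyridin-2-ylmethyl group at the chain end would read the same remains open, as does whether furan-2-yl matches 2-hydroxy-3-methoxyphenyl with cyclohexyl on the core.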